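The compounds below may be only part of what the source reports. "The series", "measured", "known", "first", "only" and "open" are said of these compounds alone.

Measured so far in an in vitro functional assay on cells (Fibroblast) for agonist activity at Alpha-1B adrenergic receptor (Homo sapiens); a higher number here means that more compound is needed for the effect, a lower number that less compound is needed:

Compound 1, `Cn1nccc1-c1ccccc1NCC1=NCCN1`. In this assay compound 1 gives < 100000 nM, which is a limit of the assay and not a number.
Compound 2, `Cn1ccc(-c2ccccc2NCC2=NCCN2)n1`. In this assay compound 2 gives 50.1 nM.
Compound 3, `Cn1cccc1-c1ccccc1NCC1=NCCN1`. In this assay compound 3 gives < 100000 nM, again a limit of the assay rather than a number.

Compound 3 thus stands only at a limit, and the limit of < 100000 nM in this assay, at which 2 of the 3 values shown sit, marks the point at which it sits together with compound 1; compound 2 alone returns a number. The steps a step that the limit leaves unreadable from compound 1 to compound 2, a step that the two limits leave unreadable from compound 1 to compound 3 and a step that the limit leaves unreadable from compound 2 to compound 3 all remain unreadable in size, so none of them gives a measured distance between the three five-membered rings at this position.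

Compound 4, `Cn1ccnc1-c1ccccc1NCC1=NCCN1`, differs from compound 3 in one place: 1-methyl-1H-imidazol-2-yl in place of 1-methyl-1H-pyrrol-2-yl on an aromatic carbon. All three measured steps exchange the same kind of ring at the same carbon, so they bear directly on this change, yet none reads as a number, and no direction can be taken from them. The expectation for compound 4 therefore rests on the spread of the three values, with compound 2 showing that a number is reachable within this series. Compound 4 is expected to give an estimate of 3000 nM, with a range from 100 nM to 100000 nM. The expected step that the limit leaves unreadable from compound 3 to compound 4 is, on this basis, a guess whose direction the data cannot fix.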

Compound 4, half-maximal effective concentration: 39.8 nM
For compound 4 the middle estimate is 75-fold (1.88 log units) above the measured one; the measured number lies below the stated range.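

With compound 4, a second ring at this aromatic carbon returns a number in this assay, and the exchange of 1-methyl-1H-pyrazol-3-yl for 1-methyl-1H-imidazol-2-yl gives a 1.3-fold lower number from compound 2 to compound 4 (0.10 log units; within the scatter), so these two rings cannot be told apart here. The steps from compound 1 and compound 3 to compound 4 cannot be read, since compound 1 and compound 3 each stand only at a limit of the assay: the limit of < 100000 nM in this assay, at which 2 of the 4 values shown sit. A second nitrogen in the ring does not by itself separate the series, as the 1-methyl-1H-pyrazol-5-yl ring of compound 1 also holds two nitrogens and goes against any such pattern.

The compounds shown leave open how far the number would move with a six-membered ring such as pyridine at this carbon. They also leave open whether the same ring without its methyl group, or an open amine, would still return a number.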